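From phenyl to 2-methoxyphenyl without a baseline number

This account rests on a few compounds, and the source may have more. Where it says the series, first, only, none or still open, it means among the compounds named here.

Measured in a physicochemical assay for lipophilicity, at pH 7.4 (on this read-out lower numbers stand for lower lipophilicity and higher numbers for higher lipophilicity), compound 1 `CNc1ccnc2c(O)c(-c3nc(C)n[nH]3)ncc12` gives -0.2 and compound 2 `Cc1n[nH]c(-c2ncc3c(N4CCCCS4(=O)=O)ccnc3c2O)n1` gives 1.5. Going by the values given here, the one measured step is a number 1.70 log units higher from compound 1 to compound 2 (beyond the scatter), and it involves other groups at another place, so it bears on the present change only loosely.

Compound 3 `Cc1n[nH]c(-c2ncc3c(-c4ccccc4)ccnc3c2O)n1` has no number to start from, its result being "not determined" (no result reported). Compound 4 `COc1ccccc1-c1ccnc2c(O)c(-c3nc(C)n[nH]3)ncc12` differs from it by methoxy in place of hydrogen on an aromatic carbon, with methoxy in place of hydrogen, ortho to a large group. A small step in this assay is expected, with no direction favoured and probably none beyond the scatter. The estimate therefore leans on compound 2 at 1.5 as the nearest measured anchor. Compound 4 is expected at 1.8, within an estimated range from 1 to 2.6.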

Compound 4, distribution coefficient: 3.2
Compound 4: middle estimate off by 1.40 log units, on the low side; the measured number lies above the stated range.
By their numbers in this assay, from the lowest: compound 1; then compound 2; then compound 4.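

With 2-methoxyphenyl on this aromatic carbon, the reading in this assay is a number 1.70 log units higher from compound 2 to compound 4 (beyond the scatter) and a number 3.40 log units higher from compound 1 to compound 4 (beyond the scatter). Compound 4 therefore stands highest of the three compounds with numbers, and the substituent at this one place spans a wider range than compound 1 and compound 2 alone had shown. No evidence at hand accounts for the size of these steps.

From the compounds shown here alone, with no number for compound 3, the share of the methoxy group in these steps remains open. Also open, going by these compounds, is how an ethoxy group or a carboxylic acid would read in place of methoxy.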